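Cytotoxicity notes: methyl for trifluoromethyl on compound 1

This account rests on a few compounds, and the source may have more. Where it says the series, first, only, none or still open, it means among the compounds named here.

Compound 1 `O=C(O)CCCCCCC(=O)Nc1ccc(C2=C(c3ccc(O)cc3)C3CC(S(=O)(=O)Oc4ccc(C(F)(F)F)cc4)C2O3)cc1` is tested in an ADME assay on Vero cells (Chlorocebus sabaeus) for inhibition, read by MTT assay, with a stated time of 72 h; a lower number here means a stronger inhibitor, a higher number a weaker inhibitor. There compound 1 gives > 100000 nM, which is a limit of the assay and not a number. Two further compounds stand on the same footing. Compound 2 `O=C(O)CCCCCCC(=O)Nc1ccc(OS(=O)(=O)C2CC3OC2C(c2ccc(O)cc2)=C3c2ccc(O)cc2)cc1` gives > 100000 nM in this assay, again a limit. Compound 3 `COC(=O)CCCCCCC(=O)Nc1cccc(OS(=O)(=O)C2CC3OC2C(c2ccc(O)cc2)=C3c2ccc(O)cc2)c1` gives > 100000 nM in this assay, also a limit. Compound 1 thus sits at the limit of > 100000 nM in this assay, at which 3 of the 3 values shown sit, and nothing among the shown values separates it from the others. Among the compounds with values here, no pair of measured compounds differs in a single place, so no measured step is available.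

Compound 4 `Cc1ccc(OS(=O)(=O)C2CC3OC2C(c2ccc(NC(=O)CCCCCCC(=O)O)cc2)=C3c2ccc(O)cc2)cc1` departs from compound 1 by methyl in place of trifluoromethyl on an aromatic carbon. With three limits shown and no measured step to draw on, a step of none beyond the scatter is expected in this assay, most probably ending again at a limit rather than a number. Compound 4 is therefore expected to give 200000 nM in this assay, within a range from 100000 nM to 500000 nM. The step expected is a step that the limit leaves unreadable from compound 1 to compound 4.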

Compound 4, half-maximal inhibitory concentration: > 100000 nM
Compound 4: a limit, no number (the forecaster's own chance of this, stated with the estimate: 85%); the middle value is on the limit's open side.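

No step can be read between compound 1 and compound 4 in this assay, as both values are limits and not numbers. The compounds shown leave open whether any of them differs from the others in this assay: the limit of > 100000 nM in this assay, at which 4 of the 4 values shown sit.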